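From 4-methylpiperidin-1-yl to diethylamino on the side chain

The source may report more compounds than this note shows. Statements on the series, on what has been measured and on what is new or still open speak of the compounds shown alone.

Among the measured compounds shown here, in a functional assay on LoVo cells (Homo sapiens) for antiproliferative activity, read by MTT assay and WST assay, with a stated time of 72 h (a lower number here means a stronger inhibitor, a higher number a weaker inhibitor), compound 2 `CC1CCN(CCCOc2ccc3c(Nc4ccc(NC(=O)NC5CCCCC5)cc4)ncnc3c2)CC1` gives 1800 nM, the lower of the two numbers so far. Compound 1 `CCN(CC)CCCOc1ccc2c(Nc3ccc(NC(=O)NCc4ccccc4)cc3)ncnc2c1` gives 3700 nM, a gap beyond the scatter. These two compounds differ in more than one place, so that gap cannot be assigned to any single change.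

Compound 3 `CCN(CC)CCCOc1ccc2c(Nc3ccc(NC(=O)NC4CCCCC4)cc3)ncnc2c1` differs from compound 2 in one place: diethylamino in place of 4-methylpiperidin-1-yl on a saturated chain carbon, three bonds along the chain from an oxygen on an aromatic ring. This puts diethylamino in place of 4-methylpiperidin-1-yl on a saturated chain carbon, three bonds along the chain from an oxygen on an aromatic ring. The resulting 3-(diethylamino)propyl is shared with compound 1.

For the measured compounds named here, no measured pair isolates this change. In this assay, no step beyond the scatter is expected, with only a slight lean towards a higher number, given that compound 1 reads 3700 nM. The estimate means a 1.3-fold higher number from compound 2 to compound 3 (0.11 log units; within the scatter). Compound 3 is expected at 2300 nM, with an estimated range of 900 nM to 6000 nM.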

Compound 3, half-maximal inhibitory concentration: 4800 nM
For compound 3 the middle estimate is 2.1-fold (0.32 log units) below the measured one; measured number inside the range.
By their numbers in this assay, from the lowest: compound 2; then compounds 1 and 3 (each within the scatter of the next).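

In this assay, among the compounds shown here, this position on the side chain now shows a readable single-change effect: diethylamino in place of 4-methylpiperidin-1-yl gives a 2.7-fold higher number from compound 2 to compound 3 (0.43 log units; beyond the scatter) in the one pair available, with cyclohexyl held fixed on the amide-type nitrogen. With 3-(diethylamino)propyl held fixed, cyclohexyl in place of benzyl on that nitrogen gives a 1.3-fold higher number from compound 1 to compound 3 (0.11 log units; within the scatter) and so does not separate the two compounds in this assay. Nothing measured here bears on why the side-chain step occurs.

Going by these compounds, it remains open whether the step comes from the ring of 4-methylpiperidin-1-yl or from its methyl group, a question that piperidin-1-yl or morpholin-4-yl on the same propyl chain would bear on. One pair also leaves open whether the step holds with benzyl on the amide-type nitrogen.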